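A few compounds are considered here, and "the series" means these few. Any claim that something is new, unique, unknown or untested is made for them only; others in the source may bear on it.

Three compounds share one core and differ only in the group carried on a carbonyl carbon. Compound 1 `COc1cc(-c2nn(-c3cccc(NC(=O)c4cccc(C(F)(F)F)c4)c3)cc2-c2ccncc2)ccc1Cl` bears 3-(trifluoromethyl)phenyl there, and in a functional assay on OVCAR-4 cells (Homo sapiens) for inhibition, read by sulforhodamine B assay, with a stated time of 48 h (a higher number here means a weaker inhibitor of growth, a lower number a stronger inhibitor of growth), compound 1 gives 2280 nM. Compound 2 `COc1cc(-c2nn(-c3cccc(NC(=O)Nc4ccc(Cl)c(Cl)c4)c3)cc2-c2ccncc2)ccc1Cl` gives 1290 nM, and compound 3 `COc1cc(-c2nn(-c3cccc(NC(=O)Nc4ccc(Cl)c(C(F)(F)F)c4)c3)cc2-c2ccncc2)ccc1Cl` gives 1290 nM, so compound 3 stands level with compound 2 and the two share the lowest numbers of the three; no change at the digits printed from compound 2 to compound 3 (within the scatter). Against compound 1 the gap is a 1.8-fold lower number from compound 1 to compound 3 (0.25 log units; within the scatter), and likewise a 1.8-fold lower number from compound 1 to compound 2 (0.25 log units; within the scatter).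

Compound 4 `COc1cc(-c2nn(-c3cccc(NC(=O)c4ccccc4)c3)cc2-c2ccncc2)ccc1Cl` has not yet been measured. It differs from compound 3 in one way: phenyl in place of (4-chloro-3-(trifluoromethyl)phenyl)amino on a carbonyl carbon. The measured step that bears on it is the reverse of a 1.8-fold lower number from compound 1 to compound 3 (0.25 log units; within the scatter), since compound 1 also carries a carbon-linked ring rather than an amino-linked one on that carbonyl. Going by the values given here, no measured step shows what removing trifluoromethyl and chloro from the ring does on its own; no change at the digits printed from compound 2 to compound 3 (within the scatter) only exchanges one of these groups for the other. Compound 4 is therefore expected to come out near the number of compound 1. The expected step is a 1.9-fold higher number from compound 3 to compound 4 (0.29 log units; within the scatter), a size that need not rise beyond the scatter. In this assay the estimate for compound 4 is 2500 nM, with a range from 1000 nM to 6500 nM.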

Compound 4, concentration for 50% growth inhibition: 1170 nM
Compound 4: the middle estimate sits 2.1-fold (0.33 log units) above what was measured; measured number inside the range.
By their numbers in this assay, from the lowest: compounds 4, 2, 3 and 1 (each within the scatter of the next).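

In this assay, phenyl in place of (4-chloro-3-(trifluoromethyl)phenyl)amino on the carbonyl carbon gives a 1.1-fold lower number from compound 3 to compound 4 (0.04 log units; within the scatter), and phenyl in place of (3,4-dichlorophenyl)amino gives a 1.1-fold lower number from compound 2 to compound 4 (0.04 log units; within the scatter), so here the amino link and both ring substituents can go together without a step beyond the scatter. The earlier compounds shown here only exchanged trifluoromethyl for chloro, whereas hydrogen in place of trifluoromethyl now gives a 1.9-fold lower number from compound 1 to compound 4 (0.29 log units; within the scatter), so the ring without that group also cannot be told apart from the ring that carries it. No measured evidence accounts for these steps.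

Going by these compounds, all four compounds remain within the scatter of the next, so this position has yet to show a group that moves the number clearly, and it stays open whether an amine or a carboxylic acid on the phenyl, or a longer chain in place of the ring on the carbonyl carbon, would do so. The shared core is the same throughout, so these compounds also leave open what changes elsewhere in the structure would do.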